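Swapping 3,4-dimethoxyphenyl for 3,4-difluorophenyl on the amide nitrogen

The source may hold more compounds than are shown below. What is called first, only, known or untested is meant among the compounds shown, and "the series" means these compounds.

Of the compounds shown here, two sharing one core have been measured in a functional assay on HT-29 cells (Homo sapiens) for cytotoxicity, read by MTT assay, with a stated time of 72 h; a lower number here means a stronger inhibitor, a higher number a weaker inhibitor. Compound 1 (`O=C(CN1CCN(c2nnc(Cc3ccccc3)c3ccccc23)CC1)Nc1ccc(F)c(C(F)(F)F)c1`) gives 4590 nM, while compound 2 (`COc1ccc(NC(=O)CN2CCN(c3nnc(Cc4ccccc4)c4ccccc34)CC2)cc1OC`) gives 145000 nM, the higher of the two numbers and so the weaker inhibitor. Compound 3 (`O=C(CN1CCN(c2nnc(Cc3ccccc3)c3ccccc23)CC1)Nc1ccc(F)c(F)c1`) is next, and it departs from compound 2 as follows: 3,4-difluorophenyl in place of 3,4-dimethoxyphenyl on an amide-type nitrogen. In words, it carries 3,4-difluorophenyl in place of 3,4-dimethoxyphenyl on an amide-type nitrogen.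

Going by the values given here, only one measured step bears on this change: a 32-fold higher number from compound 1 to compound 2 (1.50 log units; beyond the scatter). That step is large and beyond the scatter, and it changes the same place in the molecule. Like compound 1, compound 3 has fluorine on the phenyl ring, but it has no trifluoromethyl group, so this single pair offers only partial guidance. A large move to a lower number is expected, recovering most but not all of that step. The expected change is a 12-fold lower number from compound 2 to compound 3 (1.08 log units; beyond the scatter). For compound 3, the estimated value in this assay is 12000 nM, with an expected range of 3500 nM to 45000 nM.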

Compound 3, half-maximal inhibitory concentration: 9510 nM
For compound 3 the middle estimate is 1.3-fold (0.10 log units) above the measured one, and the stated range covers the measured number.
By their numbers in this assay, from the lowest: compound 1; then compound 3; then compound 2.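

In this assay the change to 3,4-difluorophenyl gives a 15-fold lower number from compound 2 to compound 3 (1.18 log units; beyond the scatter) and so shows that a trifluoromethyl group is not needed for a number well below that of compound 2, since fluorine alone on the phenyl ring recovers most of the ground. Fluoro in place of trifluoromethyl on an aromatic carbon gives only a 2.1-fold higher number from compound 1 to compound 3 (0.32 log units; beyond the scatter) and this modest step, though beyond the scatter, is much smaller than the step from the dimethoxy compound, so the large difference at this position goes mainly with the 3,4-dimethoxyphenyl group in compound 2. Nothing among the data shown accounts for this difference in terms of mechanism.

From the compounds shown here alone, all three compounds carry a disubstituted phenyl ring on the amide-type nitrogen, so it remains open whether an unsubstituted phenyl, a single fluorine or a single methoxy group would fall nearer to compound 3 or to compound 2. Going by these compounds, it also remains open how a chloro group, an amine or a saturated cyclohexyl ring in place of the phenyl would read in this assay at this same position.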